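Adding a 4-acetylphenyl group to compound 2

A few compounds are considered here, and "the series" means these few. Any claim that something is new, unique, unknown or untested is made for them only; others in the source may bear on it.

Among the measured compounds shown here, compound 2 `O=C(CCc1cccc2c1C(O)OC2)Nc1ccccc1` gives 42000 nM in an ADME assay on WI-38 cells (Homo sapiens) for cytotoxicity, read by MTT assay, with a stated time of 72 h (a higher number here means a weaker inhibitor, a lower number a stronger inhibitor), and so holds the only actual number so far, a weak reading for the series. Compound 1 `CC(=O)c1ccc(-c2cccc(NC(=O)CCc3ccc4c(c3)COB4O)c2)cc1` reads > 100000 nM in this assay as a limit of the assay and not a number. Compound 1 also carries a 4-acetylphenyl group, although its core differs from that of compound 2.

The next compound, compound 3 `CC(=O)c1ccc(-c2cccc(NC(=O)CCc3cccc4c3C(O)OC4)c2)cc1`, is reached through one change: 4-acetylphenyl in place of hydrogen on an aromatic carbon, with the new group placed on an aromatic carbon, meta to a large group. For the measured compounds named here, no step between measured compounds exists to size this change, so any forecast is loose. Going by the values given here, the sole guide is compound 1 at its limit of > 100000 nM and this points toward weaker inhibition, if anything. The expected outcome is a 1.4-fold higher number from compound 2 to compound 3 (0.15 log units; within the scatter) in this assay and this estimated move is no larger than the usual scatter, though a reading at the assay limit would not surprise. Compound 3 is estimated at 60000 nM with an expected range from 20000 nM to 130000 nM for its measurement.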

Compound 3, half-maximal inhibitory concentration: > 100000 nM
Compound 3: only a limit was reported (the forecaster's own chance of this, stated with the estimate: 40%); at least 1.6-fold (0.22 log units) between middle value and limit.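

In this assay, replacing hydrogen with 4-acetylphenyl on this aromatic carbon, meta to a large group, gives an at least 2.3-fold higher number from compound 2 to compound 3 (0.37 log units; beyond the scatter), so this single change now has a measured direction: toward a weaker reading. Compound 3 gives > 100000 nM, which is a limit of the assay and not a number, so the step has a lower bound but no upper end. The step from compound 1 to compound 3, where the cores differ, cannot be read, and the two compounds can only be said to share the same ceiling: the limit of > 100000 nM in this assay, at which 2 of the 3 values shown sit.

The compounds shown leave open whether the whole 4-acetylphenyl group is needed for this shift or whether a plain phenyl would give the same step, and what an amine or a carboxylic acid in place of the acetyl would do to the reading. They also leave open whether 4-acetylphenyl would give a step of similar size on another aromatic carbon of the same ring, and, with two of the three values at a limit, how far above it compound 1 and compound 3 truly lie.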